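The source may hold more compounds than are shown below. What is called first, only, known or untested is meant among the compounds shown, and "the series" means these compounds.

Compound 1 `CCOc1c(NC)cnn(C)c1=O` and compound 2 `CCOc1c(N(CC)CC)cnn(C)c1=O` share one core and differ in a single substituent. In a functional assay on the whole organism (strain Wistar) for inhibition, with Rattus norvegicus as the target, read by paw edema, with stated times of 30 min and 3 h, at a dose of 100 mg/kg by the oral route (on this read-out higher numbers stand for a stronger effect at the one dose given and lower numbers for a weaker effect), compound 1 gives 31.1%, and in this assay compound 2 gives 32.5%. The step of a number 1.4 percentage points higher from compound 1 to compound 2 (within the scatter) means the two numbers cannot be told apart, so compound 2 stands beside compound 1 rather than ahead of it. Compound 3 `CCOc1ccnn(C)c1=O` carries the change (hydrogen in place of diethylamino on an aromatic carbon), where the diethylamino group leaves and only hydrogen enters at that aromatic carbon. For the measured compounds named here, the single measured step, which swapped one amino group for another, stayed within the scatter; no measured step shows what happens when the group is removed altogether. The expected step of a number 6.5 percentage points lower from compound 2 to compound 3 (within the scatter) is therefore small, with the uncertainty leaning toward a lower number. For compound 3 the estimated value in this assay is 26%, expected to fall between 10% and 42%.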

Compound 3, a percentage reported as inhibition, in the whole organism at one dose (the size of the read-out at that dose, not a potency): -12.2%
Compound 3: the middle estimate sits 38.2 percentage points above what was measured, outside the stated range (below it).
By their numbers in this assay, from the lowest: compound 3; then compounds 1 and 2 (each within the scatter of the next).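

Hydrogen at this aromatic carbon behaves very differently from either amino group in this assay: hydrogen in place of diethylamino gives a number 44.7 percentage points lower from compound 2 to compound 3 (beyond the scatter), and hydrogen in place of methylamino gives a number 43.3 percentage points lower from compound 1 to compound 3 (beyond the scatter). The position that seemed indifferent when one amino group replaced another is therefore not indifferent to losing the amino group altogether, and compound 3 gives -12.2%, a reading below zero. Nothing measured here explains this loss.

On these data alone, it remains open whether the amino nitrogen itself matters or any substituent at this carbon would do, which a methoxy group or a chlorine atom there could help separate. The compounds shown also do not tell whether an unsubstituted amino group or a ring amine such as morpholine would read like compound 1 and compound 2.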